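Triazole nucleosides: pentyl, hydroxymethyl, pyridin-2-yl

The compounds below may be only part of what the source reports. "The series", "measured", "known", "first", "only" and "open" are said of these compounds alone.

Measured compounds:
Compound 1 `CCCCCCc1cn([C@@H]2O[C@H](CO)[C@@H](O)[C@H]2O)nn1`, in a functional assay on CCRF-CEM cells (Homo sapiens) (a lower number here means a stronger inhibitor, a higher number a weaker inhibitor), compound 1 gives > 200000 nM, a limit.
Compound 2 `OCc1cn([C@@H]2O[C@H](CO)[C@@H](O)[C@H]2O)nn1`, in this assay compound 2 gives > 200000 nM, a limit.

Among the compounds with values here, compound 2 stands on no number at all: its value in this assay is a limit, and the only other value shown, that of compound 1, is a limit as well. Within the data shown here, the one step between them, a step that the two limits leave unreadable from compound 1 to compound 2, cannot be read, and the limit of > 200000 nM in this assay, at which 2 of the 2 values shown sit, is all the evidence there is.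

The next compound, compound 3 `OC[C@H]1O[C@@H](n2cc(-c3ccccn3)nn2)[C@H](O)[C@@H]1O`, carries pyridin-2-yl in place of hydroxymethyl on an aromatic carbon. Among the measured compounds shown here, no measured step bears on this change; the step from compound 1 to compound 2 sits between two limits and gives neither a size nor a direction. In this assay the expectation for compound 3 therefore rests on nothing but the two limits, and the most likely outcome is a further limit, with the estimated step of a number no higher from compound 2 to compound 3 (the limit leaves the size open) being unreadable in the same way. The estimate for compound 3 is 200000 nM, within 50000 nM to 1000000 nM, with a limit the expected report.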

Compound 3, half-maximal inhibitory concentration: 245000 nM
Compound 3: middle estimate off by 1.2-fold (0.09 log units), on the low side; the range from low to high includes it.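

In this assay compound 3 gives 245000 nM. Within the data shown here, compound 1 and compound 2 each stand only as a limit, so the steps from either of them to compound 3 cannot be read and no new step results. The compounds shown leave open whether changing the group on this aromatic carbon of the shared core shifts the value at all.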